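A few compounds are considered here, and "the series" means these few. Any claim that something is new, unique, unknown or untested is made for them only; others in the source may bear on it.

Working notes on the series

For the measured compounds named here, the shared core of compound 1 `CN(C)c1nc(N)nc2c1ncn2/C=C1/CC1(CO)CO` carries three different groups at the one varied position across compound 2 `Nc1nc(OCc2ccccc2)c2ncn(/C=C3/CC3(CO)CO)c2n1` and compound 3 `CCCSc1nc(N)nc2c1ncn2/C=C1/CC1(CO)CO`. In an ADME assay on CCRF-HSB-2 cells (Homo sapiens) for cytotoxicity, with a stated time of 7 days (a lower number here means that less compound is tolerated, a higher number that more compound is tolerated), compound 1 gives > 20000 nM, which is a limit of the assay and not a number. In this assay compound 2 likewise gives > 20000 nM, again a limit. Going by the values given here, compound 3 is the only member with a number, giving 98000 nM in this assay; the other two values sit at the limit of > 20000 nM in this assay, at which 2 of the 3 values shown sit. Hence the measured steps are unreadable: a step that the two limits leave unreadable from compound 1 to compound 2, a step that the limit leaves unreadable from compound 1 to compound 3 and a step that the limit leaves unreadable from compound 2 to compound 3.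

Compound 4 `CC(C)CNc1nc(N)nc2c1ncn2/C=C1/CC1(CO)CO` is the next member, differing from compound 3 by isobutylamino in place of propylsulfanyl on an aromatic carbon. None of the three steps above gives a readable size, so no direction can be taken from them; all three compounds are, however, tolerated at or beyond the limit. Compound 4 is therefore expected to land in the same weakly cytotoxic region, with a step of a 1.6-fold lower number from compound 3 to compound 4 (0.21 log units; within the scatter) that is expected to stay within the scatter. The estimate for compound 4 in this assay is 60000 nM, ranging from 15000 nM to 200000 nM.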

Compound 4, half-maximal cytotoxic concentration: > 20000 nM
Compound 4 gave a limit, no number; the forecaster's own chance of this, stated with the estimate: 55%; the middle value lies beyond the limit too.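

In this assay compound 4 gives > 20000 nM, a limit and not a number. No step between compound 4 and compound 1, compound 2 or compound 3 can be read: the limit of > 20000 nM in this assay, at which 3 of the 4 values shown sit.

The compounds shown leave open how far the tolerated concentrations of the four compounds differ from one another.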